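Phenyl on the ring amide nitrogen of compound 1

The source may hold more compounds than are shown below. What is called first, only, known or untested is meant among the compounds shown, and "the series" means these compounds.

Measured compounds in a functional assay on MDA-MB-361 cells (Homo sapiens) for antiproliferative activity, read by MTT assay, with a stated time of 72 h; a lower number here means a stronger inhibitor, a higher number a weaker inhibitor:
compound 1 `CCOC(=O)c1c[nH]nc1N/C=C1\C(=O)NN=C1c1ccccc1`: 121000 nM
compound 2 `O=C1NN=C(c2ccccc2)/C1=C/Nc1cc[nH]n1`: 95300 nM
compound 3 `CSC[C@H](N/C=C1\C(=O)NN=C1c1ccccc1)C(=O)O`: 97400 nM

Compound 1 gives the highest of the three numbers, but its gaps to compound 2 and compound 3 are both within the scatter, so the three stand level. The two measured steps, a 1.3-fold lower number from compound 1 to compound 2 (0.10 log units; within the scatter) and a 1.0-fold higher number from compound 2 to compound 3 (0.01 log units; within the scatter), touch other positions and both stay within the scatter. Compound 4 `CCOC(=O)c1c[nH]nc1N/C=C1\C(=O)N(c2ccccc2)N=C1c1ccccc1` differs from compound 1 by phenyl in place of hydrogen on an amide-type nitrogen in a ring. Going by the values given here, no measured step bears on that position, so no step beyond the scatter is expected, as a 1.2-fold lower number from compound 1 to compound 4 (0.08 log units; within the scatter). Compound 4 is therefore estimated at 100000 nM, in the range 30000 nM to 300000 nM.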

Compound 4, half-maximal inhibitory concentration: 24700 nM
Compound 4: the middle estimate sits 4.0-fold (0.61 log units) above what was measured, and the stated range ends above it.
By their numbers in this assay, from the lowest: compound 4; then compounds 2, 3 and 1 (each within the scatter of the next).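

In this assay, going by these compounds alone, phenyl in place of hydrogen on the amide-type nitrogen in the ring gives a 4.9-fold lower number from compound 1 to compound 4 (0.69 log units; beyond the scatter), the only step here that lies beyond the scatter. Within the data shown here, this position therefore responds to substitution, whereas the two changes elsewhere in the earlier compounds left the number within the scatter. No evidence at hand accounts for this step.

On these data alone, whether methyl, benzyl, or a phenyl carrying an amine or a carboxylic acid would give a similar step on this nitrogen remains open. Also open, as far as these compounds go, is whether phenyl here would act alike on compound 2 and compound 3.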